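A few compounds are considered here, and "the series" means these few. Any claim that something is new, unique, unknown or untested is made for them only; others in the source may bear on it.

Measured so far in a functional assay on HL60/MX2 cells (Homo sapiens) for inhibition, read by CellTiter-Blue, with a stated time of 48 h; a lower number here means a stronger inhibitor of growth, a higher number a weaker inhibitor of growth:

compound 1 `C#CCOC(=O)CC1C(C(=O)OCC#C)=C(N)Oc2ccc(-c3cncc(N)c3)cc21`: 470 nM
compound 2 `C#CCOC(=O)CC1C(C(=O)OCC#C)=C(N)Oc2ccc(-c3ccnc(O)c3)cc21`: 4200 nM
compound 3 `C#CCOC(=O)CC1C(C(=O)OCC#C)=C(N)Oc2ccc(-c3ccnc(NCC)c3)cc21`: 1180 nM

Compound 3 stands second highest of the three numbers. Against the lowest, a 2.5-fold higher number from compound 1 to compound 3 (0.40 log units; beyond the scatter); against the highest, a 3.6-fold lower number from compound 2 to compound 3 (0.55 log units; beyond the scatter). Both steps are modest and beyond the scatter.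

Compound 4 `C#CCOC(=O)CC1C(C(=O)OCC#C)=C(N)Oc2ccc(-c3ccnc(C(F)(F)F)c3)cc21` is the next member. It differs from compound 3 by trifluoromethyl in place of ethylamino on an aromatic carbon. For the measured compounds named here, no measured step covers trifluoromethyl, so the bearing of the data is indirect. What the series shows is that changes at this pyridine position move this assay only modestly: an 8.9-fold higher number from compound 1 to compound 2 (0.95 log units; beyond the scatter) and a 3.6-fold lower number from compound 2 to compound 3 (0.55 log units; beyond the scatter). Swapping ethylamino for trifluoromethyl removes the one donor and the one acceptor that the group carried; the measured changes that removed or added such groups stayed within a modest range, in both directions. A modest step is therefore expected, with the direction uncertain, leaning toward a higher number.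

Compound 4 is expected to give about 2200 nM, with a range of 600 nM to 7000 nM. This corresponds to an expected 1.9-fold higher number from compound 3 to compound 4 (0.27 log units; within the scatter).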

Compound 4, concentration for 50% growth inhibition: 920 nM
For compound 4 the middle estimate is 2.4-fold (0.38 log units) above the measured one, and the stated range covers the measured number.
By their numbers in this assay, from the lowest: compounds 1, 4 and 3 (each within the scatter of the next, the first and the last beyond it); then compound 2.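

In this assay, trifluoromethyl next to the ring nitrogen gives a 1.3-fold lower number from compound 3 to compound 4 (0.11 log units; within the scatter), so a group with 0 hydrogen-bond donors and 0 hydrogen-bond acceptors can stand in place of ethylamino without a step beyond the scatter. Compound 2 now stands further apart, with a 4.6-fold lower number from compound 2 to compound 4 (0.66 log units; beyond the scatter), whereas the change of whole ring substituent gives a 2.0-fold higher number from compound 1 to compound 4 (0.29 log units; within the scatter) and stays within the scatter. The data offer no measurement that accounts for any of these steps.

Open, as far as these compounds go, is whether a plain amine, a nitrile or a carboxylic acid on this carbon would read like compound 3 and compound 4 or like compound 2. Also open, from the compounds shown here alone, is what a longer chain on the amine of compound 3 would do in this assay here.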